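The source may report more compounds than this note shows. Statements on the series, on what has been measured and on what is new or still open speak of the compounds shown alone.

Compound 1 `O=C1O/C(=C\Cn2cc(I)c(=O)[nH]c2=O)C(OCc2ccccc2)=C1OCc1ccccc1` and compound 2 `O=C1O/C(=C\Cn2ccc(=O)[nH]c2=O)C(OCc2ccccc2)=C1OCc1ccccc1` share one core, while compound 3 `O=c1[nH]c(=O)n(CC2CCC(CO)C2)cc1I` and compound 4 `O=c1ccn(CC2CCC(CO)C2)c(=O)[nH]1` are built on another; the difference between the two cores is not broken down here. In an ADME assay on L1210/0 cells (Mus musculus) for cytotoxicity, with a stated time of 48 h (a lower number here means a stronger inhibitor, a higher number a weaker inhibitor), compound 1 gives 7500 nM. In this assay compound 2 gives 12900 nM. The change from compound 1 to compound 2 is hydrogen in place of iodo on an aromatic carbon and it made a 1.7-fold higher number from compound 1 to compound 2 (0.24 log units; within the scatter). For compound 3 in this assay only a limit is known, > 200000 nM. This is the limit of > 200000 nM in this assay, at which 1 of the 3 values shown sits. Compound 4 has not yet been measured in this assay. The change from compound 3 to compound 4 is hydrogen in place of iodo on an aromatic carbon, the same kind of change as that from compound 1 to compound 2, though the place is now meta to a group of 8 heavy atoms rather than meta to a large group. Since the earlier step was a 1.7-fold higher number from compound 1 to compound 2 (0.24 log units; within the scatter) and lay within the scatter, the step here is expected to be small as well, a step that the limit leaves unreadable from compound 3 to compound 4. Compound 4 is accordingly estimated at 300000 nM, between 150000 nM and 1000000 nM, and is expected most likely to return only a limit again.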

Compound 4, half-maximal inhibitory concentration: > 200000 nM
Compound 4 gave a limit, no number (the forecaster's own chance of this, stated with the estimate: 85%); the middle value does not contradict the limit.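

In this assay, compound 3 and compound 4 each return only a limit, so no step can be read between them: the limit of > 200000 nM in this assay, at which 2 of the 4 values shown sit.

The compounds shown leave open whether hydrogen in place of iodo changes the read-out at all on the core of compound 3, and how that step compares with the one on the core of compound 1.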